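The source may hold more compounds than are shown below. What is called first, only, known or untested is meant among the compounds shown, and "the series" means these compounds.

Of the compounds shown here, three have so far been tested in an assay on isolated protein for inhibition of cathepsin S (Homo sapiens); a lower number here means a stronger inhibitor, a higher number a weaker inhibitor. Compound 1, `CC(=O)N1CCc2c(c(-c3ccc(OC(F)(F)F)cc3)nn2CC(O)CN2CCC(n3c(O)nc4ccccc43)CC2)C1`, gives 130 nM. Compound 2, `CC(=O)N1CCc2c(c(-c3ccc(Br)cc3)nn2CC(O)CN2CCC(n3c(O)nc4ccccc43)CC2)C1`, gives 80 nM, and the step of a 1.6-fold lower number from compound 1 to compound 2 (0.21 log units; within the scatter) stays within the scatter. Compound 3, `CC(=O)N1CCc2c(c(-c3ccc(Br)cc3)nn2CC(O)CN2CCC(n3c(O)nc4ccc(Cl)cc43)CC2)C1`, gives 120 nM, and the step of a 1.5-fold higher number from compound 2 to compound 3 (0.18 log units; within the scatter) likewise stays within the scatter. Compound 3 therefore stands within the scatter of both compound 1 and compound 2, and none of the three numbers can be told apart from the others.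

Compound 4, `CC(=O)N1CCc2c(c(-c3ccc(Br)cc3)nn2CC(O)CN2CCC(n3c(O)nc4cc(Cl)c(Cl)cc43)CC2)C1`, has not been measured. It differs from compound 3 in one place: chloro in place of hydrogen on an aromatic carbon. Among the measured compounds shown here, only one measured step resembles this change, a 1.5-fold higher number from compound 2 to compound 3 (0.18 log units; within the scatter), which also put a chloro in place of a hydrogen on the same fused ring system and left the number within the scatter. A second chloro on that ring is thus expected to change little, and the estimated step is a 1.3-fold higher number from compound 3 to compound 4 (0.10 log units; within the scatter), with no direction beyond the scatter. Compound 4 is expected to give 150 nM in this assay, most likely between 65 nM and 350 nM.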

Compound 4, half-maximal inhibitory concentration: 110 nM
Estimate against measurement, compound 4: 1.4-fold (0.13 log units) above; the measured number falls inside the stated range.
By their numbers in this assay, from the lowest: compounds 2, 4, 3 and 1 (each within the scatter of the next).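

Among the compounds shown here, the second chloro gives a 1.1-fold lower number from compound 3 to compound 4 (0.04 log units; within the scatter) in this assay and so adds a new finding: this ring carbon, ortho to a chloro group, takes a chloro with no step that can be told from the scatter. The earlier compounds shown here showed only a single chloro on this six-membered aromatic ring, whereas the full change from the unsubstituted group to 5,6-dichloro-2-hydroxy-1H-benzimidazol-1-yl gives a 1.4-fold higher number from compound 2 to compound 4 (0.14 log units; within the scatter) and also stays within the scatter. On this ring, then, neither one chloro nor two can be told apart from hydrogen in this series, a statement limited to compounds 2, 3 and 4. Nothing available here accounts for this result.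

From the compounds shown here alone, these compounds carry only chloro or hydrogen on this ring, so it remains open whether a different kind of group there, such as an amine, a carboxylic acid or a longer chain, would produce a step beyond the scatter. Going by these compounds, it also remains open whether the same chloro changes would read the same way on compound 1, which carries trifluoromethoxy in place of bromo.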